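Changing the Outer Aryl Group of Compound 2

A few compounds are considered here, and "the series" means these few. Any claim that something is new, unique, unknown or untested is made for them only; others in the source may bear on it.

Two compounds have been measured so far in a functional assay on MDA-MB-231 cells (Homo sapiens) for antiproliferative activity, read by MTT assay, with a stated time of 72 h; on this read-out higher numbers stand for weaker inhibition and lower numbers for stronger inhibition:

Compound 1, `COc1cccc(NC(=O)Nc2cccc(-c3nc(-c4ccc(NC(=O)c5cccnc5)cc4Cl)no3)c2)c1`, gives 6700 nM.
Compound 2, `O=C(Nc1cccc(-c2nc(-c3ccc(NC(=O)c4cccnc4)cc3Cl)no2)c1)Nc1ccc(Cl)c(C(F)(F)F)c1`, gives 1900 nM.

Among the compounds with values here, compound 2 stands at the lowest of these two numbers, and the one measured step between them, a 3.5-fold lower number from compound 1 to compound 2 (0.55 log units; beyond the scatter), is modest but beyond the scatter. Within the data shown here, that step exchanged only the aryl group sitting on the urea-type nitrogen, so it is the only guide for the next change.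

Compound 3, `C#Cc1cccc(NC(=O)Nc2cccc(-c3nc(-c4ccc(NC(=O)c5cccnc5)cc4Cl)no3)c2)c1`, differs from compound 2 in exactly that place: 3-ethynylphenyl in place of 4-chloro-3-(trifluoromethyl)phenyl on an amide-type nitrogen. The earlier step shows that swapping this aryl group can shift the number by a modest amount in either direction; since compound 3 carries neither the chlorine nor the trifluoromethyl of compound 2, its number is expected to move back up toward that of compound 1 rather than fall further, by a 2.1-fold higher number from compound 2 to compound 3 (0.32 log units; beyond the scatter). The expected result for compound 3 is therefore 4000 nM, with a range from 1500 nM to 11000 nM.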

Compound 3, half-maximal inhibitory concentration: > 10000 nM
Compound 3 ended at the assay's limit; the forecaster's own chance of this, stated with the estimate: 5%; at least 2.5-fold (0.39 log units) between middle value and limit.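

Compound 3 sits at a limit of this assay, not at a number: the limit of > 10000 nM in this assay, at which 1 of the 3 values shown sits. At this place on the amide-type nitrogen, the step of an at least 5.2-fold higher number from compound 2 to compound 3 (0.72 log units; beyond the scatter) shows that a lower number does not come with just any substituted phenyl, and among the groups shown 4-chloro-3-(trifluoromethyl)phenyl remains the one with the lowest number. Ethynyl in place of methoxy reads as an at least 1.4-fold higher number from compound 1 to compound 3 (0.17 log units; that floor lies within the scatter), but that floor lies within the scatter, so this step sets no order between the two and shows only that ethynyl brings no visible gain over methoxy.

The limit leaves open how far the true number of compound 3 lies from the others, and the compounds shown cannot tell whether the chlorine, the trifluoromethyl or the two together go with the lower number of compound 2. A phenyl carrying only the chlorine or only the trifluoromethyl would separate those two, and a phenyl carrying a nitrile or an amine would show how much further this place can be changed.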